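This account rests on a few compounds, and the source may have more. Where it says the series, first, only, none or still open, it means among the compounds named here.

Measured compounds:
- compound 1 `Cc1ccc(-c2c(C)nn(-c3nc(-c4ccc(Cl)c(Cl)c4)c(SC(C)C)s3)c2C(=O)O)cc1`: 3800 nM
- compound 2 `Cc1nn(-c2nc(-c3ccc(Cl)c(Cl)c3)c(SC(C)C)s2)c(C(=O)O)c1-c1cnn(C)c1`: 6800 nM
- compound 3 `Cc1nn(-c2nc(-c3ccc(Cl)c(Cl)c3)c(SC(C)C)s2)c(C(=O)O)c1-c1cccc(Cl)c1`: 13600 nM

All three share one core and differ only in the aryl group on the aromatic carbon of the five-membered ring. In a functional assay on BJAB cells (Homo sapiens) for antiproliferative activity, with a stated time of 4 days (on this read-out higher numbers stand for an effect only at larger amounts of compound and lower numbers for an effect already at smaller amounts), compound 2 gives 6800 nM and stands second highest of the three numbers; its nearest neighbour is compound 1 (a 1.8-fold higher number from compound 1 to compound 2 (0.25 log units; within the scatter)) and its furthest is compound 3 (a 2.0-fold higher number from compound 2 to compound 3 (0.30 log units; within the scatter)), both within the scatter. Among the compounds with values here, the only step beyond the scatter is a 3.6-fold higher number from compound 1 to compound 3 (0.55 log units; beyond the scatter), which is modest.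

Compound 4 `COc1ccc(C)cc1-c1c(C)nn(-c2nc(-c3ccc(Cl)c(Cl)c3)c(SC(C)C)s2)c1C(=O)O` is not yet measured. The change from compound 2 is 2-methoxy-5-methylphenyl in place of 1-methyl-1H-pyrazol-4-yl on an aromatic carbon. Within the data shown here, the steps that bear on it are the two exchanges of the pyrazolyl for a six-membered carbon ring, a 1.8-fold higher number from compound 1 to compound 2 (0.25 log units; within the scatter) read in reverse and a 2.0-fold higher number from compound 2 to compound 3 (0.30 log units; within the scatter), which point in opposite directions and are both within the scatter. The entering group carries a methyl, as in compound 1, so a number near that of compound 1 is expected, giving a step of a 1.5-fold lower number from compound 2 to compound 4 (0.18 log units; within the scatter) that is expected to stay within the scatter. Compound 4 is therefore estimated at 4500 nM, with a range from 1800 nM to 12000 nM.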

Compound 4, half-maximal effective concentration: 9500 nM
Compound 4: middle estimate off by 2.1-fold (0.32 log units), on the low side; measured number inside the range.
By their numbers in this assay, from the lowest: compounds 1, 2, 4 and 3 (each within the scatter of the next, the first and the last beyond it).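

In this assay, the 2-methoxy-5-methylphenyl group stays within the scatter of both the 1-methyl-1H-pyrazol-4-yl group (a 1.4-fold higher number from compound 2 to compound 4 (0.15 log units; within the scatter)) and the 3-chlorophenyl group (a 1.4-fold lower number from compound 3 to compound 4 (0.16 log units; within the scatter)). Against the 4-methylphenyl group it gives a step beyond the scatter (a 2.5-fold higher number from compound 1 to compound 4 (0.40 log units; beyond the scatter)), so a methyl group on the entering ring does not by itself place compound 4 within the scatter of compound 1, and both steps beyond the scatter now start from compound 1, while compound 2 stays within the scatter of compound 1. No measurement at hand explains these steps.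

The compounds shown leave open what the methoxy and methyl groups of the 2-methoxy-5-methylphenyl group each contribute. Also open, from the compounds shown here alone, is how a non-aromatic group at this place, such as an amine or a longer chain, would read out.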